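The source may hold more compounds than are shown below. What is called first, only, known or untested is meant among the compounds shown, and "the series" means these compounds.

Of the compounds shown here, three have numbers so far. In a functional assay on the whole organism (trachea) for inhibition, with Cavia porcellus as the target (on this read-out higher numbers stand for an effect only at larger amounts of compound and lower numbers for an effect already at smaller amounts), compound 1 (`CSCC(=O)N1CCSC1COc1ccccc1O`) gives 28 mg/kg, compound 2 (`COc1ccccc1OCC1N(C(=O)C[S+](C)[O-])CC[S+]1[O-]`) gives 25 mg/kg and compound 3 (`COc1ccccc1OCC1SCCN1C(=O)C(C)(C)C`) gives 24 mg/kg. Compound 3 therefore stands level with the other two, as all three values lie within the usual scatter of one another, and no order can be drawn among them.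

The next compound is compound 4 (`CNC(=O)CC(=O)N1CCSC1COc1ccccc1OC`), which has (methylcarbamoyl)methyl in place of the tert-butyl of compound 3 on a carbonyl carbon ((methylcarbamoyl)methyl in place of tert-butyl on a carbonyl carbon). Going by the values given here, no pair of measured compounds differs in one place only, so the series offers no direct step for this change. Among the compounds with values here, the only guide is indirect: compound 1 and compound 2 also lack the tert-butyl, and they differ from compound 3 in more than one place. Even so, compound 1 stays at 28 mg/kg and compound 2 at 25 mg/kg in this assay. The estimated change, a 1.3-fold higher number from compound 3 to compound 4 (0.10 log units; within the scatter), is expected to stay within the scatter, with only a slight lean towards a higher number. The new group has not been tested in this series, so the expected range is kept wide. Compound 4 is estimated at 30 mg/kg, with an expected range of 12 mg/kg to 75 mg/kg.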

Compound 4, dose for half-maximal effect: 22 mg/kg
The estimate for compound 4 lay 1.4-fold (0.13 log units) above the measured number, and the stated range covers the measured number.
By their numbers in this assay, from the lowest: compounds 4, 3, 2 and 1 (each within the scatter of the next).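

The series now has its first direct step at this place, the carbonyl carbon whose other neighbour is the amide-type nitrogen in a ring: in this assay, (methylcarbamoyl)methyl in place of tert-butyl gives a 1.1-fold lower number from compound 3 to compound 4 (0.04 log units; within the scatter) and so leaves the number within the scatter. At this place, then, a group with 4 carbon heavy atoms and no hydrogen-bond donor or acceptor can give way to one that brings in nitrogen, oxygen, a hydrogen-bond donor and a hydrogen-bond acceptor without a change that can be read on this read-out. No supporting data bear on why this exchange leaves the number level.

Going by these compounds, whether the same place would also stay level with an amine, a carboxylic acid, a phenyl ring or a longer chain on the carbonyl carbon remains open. On these data alone, the finding also rests on a single pair of compounds, so it remains unknown whether the same exchange would stay within the scatter if another part of the shared core were altered.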